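The source may report more compounds than this note shows. Statements on the series, on what has been measured and on what is new or still open speak of the compounds shown alone.

Measured so far in a functional assay on NCI60 cells (Homo sapiens) for cytotoxicity; on this read-out lower numbers stand for stronger inhibition of growth and higher numbers for weaker inhibition of growth: compound 1 `C=CCNC1=CC(=O)c2nc(-c3ccccc3)ccc2C1=O` gives 1910 nM; compound 2 `COCCCNC1=CC(=O)c2nc(-c3ccccc3)ccc2C1=O` gives 3550 nM.

Compound 2 holds the higher of the two numbers, but its nearest neighbour, compound 1, sits within the scatter of it. Compound 3 `O=C1C(NCc2ccccc2)=CC(=O)c2nc(-c3ccccc3)ccc21` has not been measured; the change is phenyl in place of 2-methoxyethyl on a saturated chain carbon bound to an amine nitrogen. Among the measured compounds shown here, the only step at this place, a 1.9-fold higher number from compound 1 to compound 2 (0.27 log units; within the scatter), exchanged one chain for another and stayed within the scatter; no measured step brings in a ring here. Compound 3 is therefore expected to shift by about a 1.4-fold lower number from compound 2 to compound 3 (0.15 log units; within the scatter), with wide uncertainty. For compound 3 the estimate in this assay is 2500 nM, between 800 nM and 8000 nM.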

Compound 3, concentration for 50% growth inhibition: 1700 nM
Compound 3: middle estimate off by 1.5-fold (0.17 log units), on the high side, within the range that was stated.
By their numbers in this assay, from the lowest: compounds 3, 1 and 2 (each within the scatter of the next, the first and the last beyond it).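

In this assay, among the compounds shown here, phenyl is the first ring at this place, on a saturated chain carbon bound to an amine nitrogen, and a 2.1-fold lower number from compound 2 to compound 3 (0.32 log units; beyond the scatter) is the first step here beyond the scatter, though only a modest one. Set against the vinyl chain, a 1.1-fold lower number from compound 1 to compound 3 (0.05 log units; within the scatter) stays within the scatter, so this ring and that short chain cannot be told apart on this read-out. Nothing measured on these compounds accounts for either step.

From the compounds shown here alone, whether the step from compound 2 follows from the entering phenyl or the leaving methoxy oxygen stays open. Also open, going by these compounds, is how a longer chain ending in phenyl, a terminal dimethylamino group or a carboxylic acid would read at this place.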